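The source may report more compounds than this note shows. Statements on the series, on what has been measured and on what is new or still open speak of the compounds shown alone.

In an ADME assay on the whole organism (strain CD) for pharmacokinetics, with Rattus norvegicus as the target, at a dose of 1 mg/kg (a lower number here means that more of the compound stays in the plasma, a higher number that more of the compound sits outside the plasma), compound 3 `CN[C@H](C)C(=O)NCc1cccc(Cn2nc(NS(=O)(=O)c3ccc(Cl)s3)c3c(OC)cccc32)c1` gives 0.79 L/kg. Compound 1 `CC(=O)NCc1cccc(Cn2nc(NS(=O)(=O)c3ccc(Cl)s3)c3c(O)cccc32)c1` gives 1.2 L/kg, within the scatter of compound 3, while compound 2 `CC(=O)NCc1cccc(Cn2nc(NS(=O)(=O)c3ccc(Cl)s3)c3c(C(C)O)cccc32)c1` gives a higher 3.5 L/kg. Compound 4 `COc1cccc2c1c(NS(=O)(=O)c1ccc(Cl)s1)nn2Cc1cccc(CNC(=O)[C@@H]2CCCCN2)c1` carries piperidin-2-yl in place of 1-(methylamino)ethyl on a carbonyl carbon. Within the data shown here, the only measured single-place step, a 2.9-fold higher number from compound 1 to compound 2 (0.46 log units; beyond the scatter), is modest and swaps hydroxy for 1-hydroxyethyl on an aromatic carbon, so it serves only as a rough gauge of size. Among the measured compounds shown here, no measured step covers the change on the carbonyl carbon. A small upward move that stays within the scatter is therefore expected in this assay, with the expected step being a 1.5-fold higher number from compound 3 to compound 4 (0.18 log units; within the scatter). For compound 4 the estimated value is 1.2 L/kg, with an expected range of 0.55 L/kg to 2.6 L/kg.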

Compound 4, volume of distribution at steady state: 2.6 L/kg
Estimate against measurement, compound 4: 2.2-fold (0.34 log units) below; the range from low to high includes it.
By their numbers in this assay, from the lowest: compounds 3 and 1 (each within the scatter of the next); then compounds 4 and 2 (each within the scatter of the next).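

In this assay, among these compounds, the group on the carbonyl carbon can shift the read-out beyond the scatter: piperidin-2-yl in place of 1-(methylamino)ethyl gives a 3.3-fold higher number from compound 3 to compound 4 (0.52 log units; beyond the scatter), the first measured step at this place. The step shows that closing the amine-bearing chain into a six-membered ring is not a neutral swap here. No measured evidence bears on why the number rises.

The ring and the extra carbon atoms cannot be separated on these compounds. A pyrrolidin-2-yl group or an open-chain 1-(ethylamino)propyl group at this place would help to tell them apart.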